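A few compounds are considered here, and "the series" means these few. Any claim that something is new, unique, unknown or untested is made for them only; others in the source may bear on it.

Measured so far in a functional assay on MCF7 cells (Homo sapiens) for cytotoxicity, read by MTT assay, with a stated time of 48 h; a lower number here means a stronger inhibitor, a higher number a weaker inhibitor:

- Compound 1 `COc1cc(-c2nnc3n2NC(c2ccco2)C(C(=O)c2ccc(Br)cc2)S3)cc(OC)c1OC`, a limit of the assay rather than a number: > 100000 nM
- Compound 2 `COc1cc(-c2nnc3n2NC(c2cccs2)C(C(=O)c2ccccc2)S3)cc(OC)c1OC`, likewise only a limit: > 100000 nM

Within the data shown here, compound 1 therefore stands at the edge of what this assay can report, and the one other value measured sits at the same edge: the limit of > 100000 nM in this assay, at which 2 of the 2 values shown sit. Nothing among these numbers separates the two compounds, and no step between measured compounds can be drawn.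

Compound 3 `COc1cc(-c2nnc3n2NC(c2ccco2)C(C(=O)c2ccc(C)cc2)S3)cc(OC)c1OC` differs from compound 1 in one place: methyl in place of bromo on an aromatic carbon. Among the measured compounds shown here, since no measured step exists to lean on, the expectation rests on compound 1 alone, which in this assay gives only a limit, > 100000 nM. Expected from that, the step that the limit leaves unreadable from compound 1 to compound 3 should be none beyond the scatter, with the real chance that compound 3 again returns a limit rather than a number. Compound 3 is expected to give 150000 nM, with a range from 40000 nM to 600000 nM.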

Compound 3, half-maximal inhibitory concentration: > 100000 nM
Compound 3 gave a limit, no number (the forecaster's own chance of this, stated with the estimate: 80%); the middle value is on the limit's open side.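

In this assay, compound 3 returns only a limit, as does compound 1, so no size can be read for the change from bromo to methyl: the limit of > 100000 nM in this assay, at which 3 of the 3 values shown sit. The compounds shown leave open how strong any of them really is, and whether swapping bromo for methyl makes any difference at all.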